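The source may hold more compounds than are shown below. What is called first, only, known or untested is meant among the compounds shown, and "the series" means these compounds.

In a physicochemical assay for solubility, at pH 7 (on this read-out lower numbers stand for lower solubility and higher numbers for higher solubility), compound 1 `CC(C)(C)C(=O)N1Cc2c(NC(=O)c3ccc(F)cc3)n[nH]c2C1(C)C` gives 235000 nM. Compound 2 `CN1CCC(C(=O)N2Cc3c(NC(=O)c4cc(F)cc(F)c4)n[nH]c3C2(C)C)CC1` gives > 225000 nM, which is a limit of the assay and not a number. Its place on the scale is therefore known only as that limit. Compound 3 `CN1CCC(C(=O)N2Cc3c(NC(=O)c4ccco4)n[nH]c3C2(C)C)CC1` differs from compound 2 in one place, with furan-2-yl in place of 3,5-difluorophenyl on a carbonyl carbon. For the measured compounds named here, no measured pair of compounds differing in one place is available to size such a change in this assay. The expectation is therefore for no change beyond the scatter, in either direction, and the estimated step is a step that the limit leaves unreadable from compound 2 to compound 3. Going by the values given here, the only number near it is that of compound 1 at 235000 nM. The expected value for compound 3 is 230000 nM, with an estimated range from 120000 nM to 400000 nM.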

Compound 3, solubility: > 225000 nM
Compound 3 was reported as a limit; the forecaster's own chance of this, stated with the estimate: 60%; the middle value is on the limit's open side.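

In this assay, for the compounds shown here, compound 2 and compound 3 are both reported only as limits of the assay, and no step between them can be read. The compounds shown leave open how far either value lies past its limit, and whether furan-2-yl in place of 3,5-difluorophenyl changes it at all.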